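A few compounds are considered here, and "the series" means these few. Any claim that something is new, unique, unknown or untested is made for them only; others in the source may bear on it.

Measured so far:
compound 1 `COc1ccccc1NC(=O)CCC(=O)OCCCCCCSc1ccc([N+](=O)[O-])c2nonc12`, 280 nM
compound 2 `O=C(CCC(=O)OCCCCCCSc1ccc([N+](=O)[O-])c2nonc12)Nc1ccc(Br)cc1`, 32000 nM
compound 3 `Cc1ccc(NC(=O)CCC(=O)OCCCCCCSc2ccc([N+](=O)[O-])c3nonc23)cc1`, 390 nM

Three compounds share one core and differ only in the aryl group on the amide-type nitrogen. Measured in an assay on isolated protein for inhibition of glutathione S-transferase Mu 2 (Homo sapiens), with a stated time of 10 min (a lower number here means a stronger inhibitor, a higher number a weaker inhibitor), compound 3 gives 390 nM, the second highest of the three numbers: the step of a 1.4-fold higher number from compound 1 to compound 3 (0.14 log units; within the scatter) lies within the scatter, while the step of an 82-fold lower number from compound 2 to compound 3 (1.91 log units; beyond the scatter) is large and beyond it. Compound 4 `O=C(CCC(=O)OCCCCCCSc1ccc([N+](=O)[O-])c2nonc12)Nc1ccc(F)c(Cl)c1` is the next member of the set, and its change from compound 3 is 3-chloro-4-fluorophenyl in place of 4-methylphenyl on an amide-type nitrogen.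

Among the compounds with values here, two measured steps bear on this change. Within the data shown here, the step of an 82-fold lower number from compound 2 to compound 3 (1.91 log units; beyond the scatter) and the step of a 110-fold higher number from compound 1 to compound 2 (2.06 log units; beyond the scatter) both show that the one halogen-bearing analogue, compound 2, gives by far the highest number, whereas the methyl- and methoxy-bearing analogues lie close together. From the compounds shown here alone, compound 4 carries two halogens on its ring and no methyl, so a higher number than compound 3 is expected, though a ring with chlorine and fluorine is untested here and the expected step of a 10-fold higher number from compound 3 to compound 4 (1.01 log units; beyond the scatter) is set smaller than the bromo step. For compound 4 the estimate is 4000 nM, with a range from 800 nM to 20000 nM.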

Compound 4, half-maximal inhibitory concentration: 470 nM
Compound 4: the middle estimate sits 8.5-fold (0.93 log units) above what was measured; the measured number lies below the stated range.
By their numbers in this assay, from the lowest: compounds 1, 3 and 4 (each within the scatter of the next); then compound 2.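

Carrying halogen on the aryl group does not by itself bring the large rise seen with compound 2: 3-chloro-4-fluorophenyl on the amide-type nitrogen gives a 1.2-fold higher number from compound 3 to compound 4 (0.08 log units; within the scatter) and a 1.7-fold higher number from compound 1 to compound 4 (0.22 log units; within the scatter) and so groups compound 4 with compound 1 and compound 3. Compound 2 is now the only outlier among the four, with a 68-fold lower number from compound 2 to compound 4 (1.83 log units; beyond the scatter) setting it apart even from the other halogen-bearing compound. Nothing available here accounts for why 4-bromophenyl departs so far from 3-chloro-4-fluorophenyl.

A 4-chlorophenyl or 4-fluorophenyl group on the same nitrogen would show whether the high number of compound 2 follows bromine or a lone halogen on the ring. From the compounds shown here alone, whether an aryl group bearing an amine or a carboxylic acid would stay with compound 1, compound 3 and compound 4 also remains open.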